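A few compounds are considered here, and "the series" means these few. Any claim that something is new, unique, unknown or untested is made for them only; others in the source may bear on it.

Compound 1 `COc1ncc(-c2ccc3c(c2)NC(=O)CO3)cc1NS(=O)(=O)c1ccc(F)cc1`: 8070 nM
Compound 2 `O=C1COc2ccc(-c3cnc(Cl)c(NS(=O)(=O)c4ccc(F)cc4)c3)cc2N1`: > 40000 nM

For the measured compounds named here, in a functional assay on A549 cells (Homo sapiens) for antiproliferative activity, read by MTT assay, with a stated time of 72 h (a lower number here means a stronger inhibitor, a higher number a weaker inhibitor), compound 1 gives 8070 nM, the only true number so far. Compound 2 gives > 40000 nM, which is a limit. Compound 3 `COc1ccc(N2C(=O)COc3ccc(-c4cnc(OC)c(NS(=O)(=O)c5ccc(F)cc5)c4)cc32)cc1` keeps the core of compound 1 and adds (4-methoxyphenyl in place of hydrogen on an amide-type nitrogen in a ring). Going by the values given here, the one measured step, an at least 4.9-fold higher number from compound 1 to compound 2 (0.69 log units; beyond the scatter), lies elsewhere on the core, so it shows only that a single change can matter. No measurement covers the amide-type nitrogen, so the direction is uncertain, with a lean towards a lower number. The expected change is a 4.0-fold lower number from compound 1 to compound 3 (0.61 log units; beyond the scatter). For compound 3 the estimated value is 2000 nM, within 300 nM to 12000 nM.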

Compound 3, half-maximal inhibitory concentration: 1350 nM
Beside the measured number, compound 3's estimate is 1.5-fold (0.17 log units) above it; low and high end bracket the measured number.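

In this assay, the amide-type nitrogen in a ring now has a measured step of its own: 4-methoxyphenyl in place of hydrogen gives a 6.0-fold lower number from compound 1 to compound 3 (0.78 log units; beyond the scatter). For the compounds shown here, the earlier pair changed another place on the core, so only this step shows that an added aromatic ring on this nitrogen is compatible with a lower number. Nothing shown gives a reason for this drop. As far as these compounds go, whether a plain phenyl, a methyl or a chain ending in an amine on this nitrogen would move the number the same way stays open. So does whether the methoxy group on the new ring matters.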